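From 3,5-dichlorophenyl to 3,4-dihydroxyphenyl in a cytotoxic series

This account rests on a few compounds, and the source may have more. Where it says the series, first, only, none or still open, it means among the compounds named here.

Of the compounds shown here, two sharing one core have been measured so far in a functional assay on MCF7 cells (Homo sapiens) for cytotoxicity, read by MTT assay, with a stated time of 72 h; a higher number here means a weaker inhibitor, a lower number a stronger inhibitor. There, compound 1 `COc1cccc(/C=C2\CCC/C(=C\c3ccccc3Br)C2=O)c1OC` gives 9700 nM and compound 2 `COc1cccc(/C=C2\CCC/C(=C\c3cc(Cl)cc(Cl)c3)C2=O)c1OC` gives 4300 nM. Compound 2 therefore holds the lower of the two numbers and is the stronger inhibitor of this pair.

The next compound, compound 3 `COc1cccc(/C=C2\CCC/C(=C\c3ccc(O)c(O)c3)C2=O)c1OC`, keeps the core and changes one group: 3,4-dihydroxyphenyl in place of 3,5-dichlorophenyl on a double-bonded chain carbon bound to a double-bonded ring carbon. The change sits on a double-bonded chain carbon bound to a double-bonded ring carbon. Going by the values given here, the only measured step at this place is a 2.3-fold lower number from compound 1 to compound 2 (0.35 log units; beyond the scatter), a modest step that replaced 2-bromophenyl with 3,5-dichlorophenyl. Neither of those groups carries hydrogen-bond donors, whereas 3,4-dihydroxyphenyl does, so that single step gives little guidance on direction. With no firm basis for a shift either way, no step beyond the scatter is expected in this assay, although the uncertainty is wide. The expected change is a 1.1-fold lower number from compound 2 to compound 3 (0.03 log units; within the scatter). In this assay, the estimated value for compound 3 is 4000 nM, with an expected range of 1300 nM to 12000 nM.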

Compound 3, half-maximal inhibitory concentration: 4700 nM
Compound 3: the middle estimate sits 1.2-fold (0.07 log units) below what was measured; the measured number falls inside the stated range.
By their numbers in this assay, from the lowest: compounds 2 and 3 (each within the scatter of the next); then compound 1.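

In this assay, the step of a 1.1-fold higher number from compound 2 to compound 3 (0.04 log units; within the scatter) shows that this place, on a double-bonded chain carbon bound to a double-bonded ring carbon, takes 3,4-dihydroxyphenyl in place of 3,5-dichlorophenyl with no difference that stands out from the scatter, even though only the entering group has hydrogen-bond donors and acceptors. The second new step, a 2.1-fold lower number from compound 1 to compound 3 (0.31 log units; beyond the scatter), is close in size to the earlier step of a 2.3-fold lower number from compound 1 to compound 2 (0.35 log units; beyond the scatter), so two groups with very different atoms each give a lower number than 2-bromophenyl, by a modest margin. Nothing measured here explains why these groups give these numbers.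

Still open, from the compounds shown here alone, is whether any group at this place can move the number well beyond this modest range, for example a phenyl ring carrying an amine or a carboxylic acid, or a pyridine ring in place of the phenyl ring. The compounds shown also leave open whether a change elsewhere on the shared core would matter more than any change at this place.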